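This account rests on a few compounds, and the source may have more. Where it says the series, first, only, none or still open, it means among the compounds named here.

Compound 1, `Cc1nc(N2CCN(C(=O)COc3ccc(Cl)cc3)CC2)c2cc(F)sc2n1`: in a functional assay on cells (Lymphocyte) (on this read-out higher numbers stand for weaker inhibition and lower numbers for stronger inhibition), compound 1 gives 3390 nM.
Compound 2, `O=C(COc1ccc(Cl)cc1)N1CCN(c2nc(-c3ccccc3)nc3sc(F)cc23)CC1`: in this assay compound 2 gives only a limit, > 10000 nM.
Compound 3, `CCOC(=O)c1nc(N2CCN(C(=O)COc3ccc(Cl)cc3)CC2)c2cc(F)sc2n1`: in this assay compound 3 gives only a limit, > 10000 nM.

Compound 3 therefore stands at the top edge of what this assay can report, and it shares that edge with compound 2 (the limit of > 10000 nM in this assay, at which 2 of the 3 values shown sit). Of the three compounds, only compound 1 has a measured number, and compound 3 sits an at least 2.9-fold higher number from compound 1 to compound 3 (0.46 log units; beyond the scatter). Compound 2 is equally far off: an at least 2.9-fold higher number from compound 1 to compound 2 (0.46 log units; beyond the scatter). Between the two limits the step is not readable: a step that the two limits leave unreadable from compound 2 to compound 3.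

Compound 4, `O=C(O)c1nc(N2CCN(C(=O)COc3ccc(Cl)cc3)CC2)c2cc(F)sc2n1`, differs from compound 3 in one place: hydrogen in place of ethyl on an oxygen next to a carbonyl group. Among the compounds with values here, no measured step touches this oxygen, so nothing directly tells how the change will read. Within the data shown here, the only clue is that compound 3 already lies beyond the reporting limit, so the starting point is weak and any step from it cannot be measured in size. Compound 4 is therefore expected to remain in the weak range, with an expected step that the limit leaves unreadable from compound 3 to compound 4, and its estimated value is 15000 nM, between 5000 nM and 50000 nM.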

Compound 4, half-maximal inhibitory concentration: > 10000 nM
Compound 4 ended at the assay's limit; the forecaster's own chance of this, stated with the estimate: 70%; the middle value is on the limit's open side.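

Replacing ethyl with hydrogen on the oxygen next to a carbonyl group turns ethoxycarbonyl into carboxy, yet compound 4 is still reported only as a limit in this assay, so this change does not bring the compound back into the range where a number can be read. Carboxy thus joins phenyl and ethoxycarbonyl as a third replacement for methyl on this aromatic carbon that reads weaker, with an at least 2.9-fold higher number from compound 1 to compound 4 (0.46 log units; beyond the scatter). Only methyl has so far given a measured number at this place, and the other compounds gather at the top edge of the read-out: the limit of > 10000 nM in this assay, at which 3 of the 4 values shown sit.

As far as these compounds go, the steps among compound 2, compound 3 and compound 4 cannot be read, so the order of phenyl, ethoxycarbonyl and carboxy stays unknown. From the compounds shown here alone, whether any group on this aromatic carbon can match or beat methyl also stays open, for instance an amine, a cyclopropyl group or a plain hydrogen.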